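The source may hold more compounds than are shown below. What is called first, only, known or untested is meant among the compounds shown, and "the series" means these compounds.

Compound 1 `Cc1c(OCCCCOc2ccc(C(=O)O)cc2)ccc(C(=O)CC2CCCC2)c1O` carries, on an oxygen on a saturated carbon, an aryl group that is the part varied across this small set. In an assay on HEK293 cells for positive allosteric modulation of metabotropic glutamate receptor 2 (Rattus norvegicus), read by thallium flux, with a stated time of 2.5 min (a lower number here means that less compound is needed, a higher number that more compound is needed for the effect), compound 1 gives 824 nM. Compound 2 `COc1ccc(C(=O)O)cc1OCCCCOc1ccc(C(=O)CC2CCCC2)c(O)c1C` gives 425 nM in this assay, and compound 3 `Cc1c(OCCCCOc2ccc(C(=O)O)c(Cl)c2)ccc(C(=O)CC2CCCC2)c1O` gives 510 nM. Compound 3 therefore stands second highest of the three numbers; its nearest neighbour is compound 2 and its furthest is compound 1, and both of those gaps lie within the scatter. The recorded steps are a 1.9-fold lower number from compound 1 to compound 2 (0.29 log units; within the scatter), a 1.6-fold lower number from compound 1 to compound 3 (0.21 log units; within the scatter) and a 1.2-fold higher number from compound 2 to compound 3 (0.08 log units; within the scatter). Compound 4 `Cc1c(OCCCCOc2ccc(F)c(C(=O)O)c2)ccc(C(=O)CC2CCCC2)c1O` has not yet been measured. It differs from compound 3 by 3-carboxy-4-fluorophenyl in place of 4-carboxy-3-chlorophenyl on an oxygen on a saturated carbon. Within the data shown here, two of the recorded steps exchanged the aryl group at this same oxygen, the one from compound 1 to compound 2 and the one from compound 2 to compound 3, and both stayed within the scatter, as did the chloro-for-hydrogen exchange from compound 1 to compound 3. Nothing in these three compounds points to a step beyond the scatter, so compound 4 is expected to show a step of a 1.0-fold lower number from compound 3 to compound 4 (0.01 log units; within the scatter) in this assay. The estimate for compound 4 is 500 nM, with a range from 220 nM to 1150 nM.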

Compound 4, half-maximal effective concentration: 699 nM
Estimate against measurement, compound 4: 1.4-fold (0.15 log units) below, and the stated range covers the measured number.
By their numbers in this assay, from the lowest: compounds 2, 3, 4 and 1 (each within the scatter of the next).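

With the 3-carboxy-4-fluorophenyl group on the oxygen on a saturated carbon, the set gains its first fluorine, and the comparisons with all three earlier compounds stay within the scatter in this assay as the record shows a 1.4-fold higher number from compound 3 to compound 4 (0.14 log units; within the scatter) and a 1.6-fold higher number from compound 2 to compound 4 (0.22 log units; within the scatter) and a 1.2-fold lower number from compound 1 to compound 4 (0.07 log units; within the scatter) in turn. The four aryl groups at this place, which carry chloro, methoxy, fluoro or no further group and whose names give the carboxy group different numbers, are therefore not separated from one another by this measurement, so this position has so far shown no step beyond the scatter. Nothing available explains why these exchanges leave the numbers so close together.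

The exchange from 4-carboxy-3-chlorophenyl to 3-carboxy-4-fluorophenyl alters the halogen and the place of the carboxy group at once, so the share of each in the step stays unresolved. From the compounds shown here alone, all four compounds carry a carboxylic acid on this aryl group, and it remains open whether a tetrazole or a primary amide in its place would also stay within the scatter.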